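This account rests on a few compounds, and the source may have more. Where it says the series, first, only, none or still open, it means among the compounds named here.

In a functional assay on A549 cells (Homo sapiens), read by MTT assay, with a stated time of 72 h (on this read-out higher numbers stand for weaker inhibition and lower numbers for stronger inhibition), compound 3 (`Nc1nc(N)c2c(-c3cccs3)cn([C@@H]3O[C@H](CO)[C@@H](O)[C@H]3O)c2n1`) gives > 20000 nM as a limit of the assay, not a number. Compound 2 (`Nc1nc(N)c2c(-c3ccco3)cn([C@@H]3O[C@H](CO)[C@@H](O)[C@H]3O)c2n1`) also gives only a limit, > 20000 nM in this case. Compound 1 (`Cc1ncnc2c1c(-c1cccs1)cn2[C@@H]1O[C@H](CO)[C@@H](O)[C@H]1O`) likewise reaches only a limit, > 20000 nM here. Among the compounds with values here, compound 3 therefore stands with the others at the limit of > 20000 nM in this assay, at which 3 of the 3 values shown sit, on the numbers so far. Compound 4 (`Nc1nc(N)c2c(-c3cc4ccccc4o3)cn([C@@H]3O[C@H](CO)[C@@H](O)[C@H]3O)c2n1`) carries 1-benzofuran-2-yl in place of thiophen-2-yl on an aromatic carbon. Within the data shown here, the only measured step of this kind, a step that the two limits leave unreadable from compound 2 to compound 3, has no readable size, so it offers no direction to carry over. The estimated change, a number no higher from compound 3 to compound 4 (the limit leaves the size open), is expected to stay within the scatter in this assay. For compound 4 the expected value is 20000 nM, with an estimated range from 6000 nM to 60000 nM.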

Compound 4, half-maximal inhibitory concentration: > 20000 nM
Compound 4: a limit, no number; the forecaster's own chance of this, stated with the estimate: 70%; the middle value sits exactly at the limit.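

Compound 4 gives only a limit, so the steps to it from compound 2 and from compound 3 cannot be read: the limit of > 20000 nM in this assay, at which 4 of the 4 values shown sit.
The compounds shown leave open whether swapping the group on the shared core alters inhibition in this assay at all.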